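The compounds below may be only part of what the source reports. "The series", "measured", "known", "first", "only" and "open" are said of these compounds alone.

Measured compounds:
compound 1 `COc1ccccc1N1CCN(CCn2c(=O)[nH]c3cc(-c4ccccc4)[nH]c3c2=O)CC1` — 0.52 nM
compound 2 `O=c1[nH]c2cc(-c3ccccc3)[nH]c2c(=O)n1CCN1CCN(c2ccccc2Cl)CC1` — 1.08 nM

For the measured compounds named here, in an assay for binding affinity to Adrenergic receptor alpha-1 (Rattus norvegicus) (on this read-out higher numbers stand for weaker inhibition and lower numbers for stronger inhibition), compound 1 gives the lowest of the two numbers; the only neighbour, compound 2, sits a 2.1-fold higher number from compound 1 to compound 2 (0.32 log units; beyond the scatter) away, a chloro in place of a methoxy on the aryl piperazine.

Compound 3 `COc1ccccc1N1CCN(CCn2c(=O)[nH]c3cc(-c4cccc(Cl)c4)[nH]c3c2=O)CC1` differs from compound 1 by chloro in place of hydrogen on an aromatic carbon. Going by the values given here, no measured step touches this phenyl ring; the step from compound 1 to compound 2 concerns a different ring and a different exchange, so it bears only indirectly. It does show that a single chloro change in this series moved the number only modestly. A small shift is therefore expected in this assay for compound 3, more likely upward than downward, possibly within the scatter, and the estimated step is a 1.6-fold higher number from compound 1 to compound 3 (0.21 log units; within the scatter). For compound 3 the estimate in this assay is 0.85 nM, with a range of 0.3 nM to 2.5 nM.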

Compound 3, inhibition constant: 19.3 nM
Beside the measured number, compound 3's estimate is 23-fold (1.36 log units) below it; the whole stated range lies below it.
By their numbers in this assay, from the lowest: compound 1; then compound 2; then compound 3.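

In this assay the phenyl ring of compound 1 turns out to be a sensitive place in the series: phenyl to 3-chlorophenyl gives a 37-fold higher number from compound 1 to compound 3 (1.57 log units; beyond the scatter) from a single added chlorine. For the compounds shown here, the only earlier step, a 2.1-fold higher number from compound 1 to compound 2 (0.32 log units; beyond the scatter), is modest and lies on the aryl piperazine, so a chloro change on one ring says little about a chloro change on the other. No evidence in hand accounts for the size of the new step.

Going by these compounds, it remains open whether this loss is specific to chloro or extends to other groups on the same carbon, such as fluoro, methyl or an amine. On these data alone, it is also open whether chloro on another carbon of this phenyl ring gives a step of similar size.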